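Cytotoxicity of Three Benzyl Variants in HEL Cells

The source may report more compounds than this note shows. Statements on the series, on what has been measured and on what is new or still open speak of the compounds shown alone.

Compound 1 `CCOC(=O)C1(Cc2ccccc2)CN(c2ccccc2)Cc2nnn(Cc3cccc(F)c3)c21`: >= 100000 nM
Compound 2 `CCOC(=O)C1(Cc2ccccc2)CN(c2ccccc2)Cc2nnn(Cc3ccc(Cl)c(Cl)c3)c21`: > 100000 nM

In an ADME assay on HEL cells (Homo sapiens) for cytotoxicity, read by microscopy, with a stated time of 3 days (a lower number here means that less compound is tolerated, a higher number that more compound is tolerated), compound 2 gives > 100000 nM, which is a limit of the assay and not a number. Compound 1 likewise stands at >= 100000 nM, also a limit. The step that the two limits leave unreadable from compound 1 to compound 2 is therefore unreadable, as the limit of > 100000 nM in this assay, at which 1 of the 2 values shown sits, and the limit of >= 100000 nM in this assay, at which 1 of the 2 values shown sits, show. Compound 3 `CCOC(=O)C1(Cc2ccccc2)CN(c2ccccc2)Cc2nnn(Cc3c(F)cccc3Cl)c21` differs from compound 2 by 2-chloro-6-fluorophenyl in place of 3,4-dichlorophenyl on a saturated chain carbon bound to an aromatic nitrogen. With both measured values at limits, no readable step bears on this change, so compound 3 is expected to remain near the same limit. The expected step is a number no higher from compound 2 to compound 3 (the limit leaves the size open). Compound 3 is estimated at 100000 nM, within 50000 nM to 200000 nM.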

Compound 3, minimum cytotoxic concentration: > 100000 nM
Compound 3 was reported as a limit; the forecaster's own chance of this, stated with the estimate: 85%; the middle value sits exactly at the limit.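

In this assay, among the compounds shown here, compound 3 gives > 100000 nM, a limit and not a number, so no step from compound 1 or compound 2 to compound 3 can be read. The compounds shown leave open at what concentration any of the three harms these cells.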